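This account rests on a few compounds, and the source may have more. Where it says the series, first, only, none or still open, it means among the compounds named here.

Notes on the lipophilicity series. Compound 1 `CSc1ccc2nc(C)cc(OCC(=O)Nc3cc(C)cc(C)c3)c2c1` gives 6.42 in a physicochemical assay for lipophilicity, read by HPLC, in phosphate buffer, measured as chromatographic lipophilicity, at pH 7.4; on this read-out lower numbers stand for lower lipophilicity and higher numbers for higher lipophilicity. Compound 2 `COc1ccc2nc(C)c(NC(=O)C(=O)Nc3cc(C)cc(C)c3)c(O)c2c1` gives 3.76 in this assay. Compound 3 `COc1ccc2nc(C)cc(OCC(=O)Nc3cc(C)ccc3OC)c2c1` gives 5.65 in this assay, which places it second highest of the three numbers: compound 1 sits above it by a gap beyond the scatter, and compound 2 sits well below it, also beyond the scatter.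

Compound 4 `COc1ccc2nc(C)cc(OCC(=O)Nc3nc(C)c(C)s3)c2c1` carries a single change from compound 3: 4,5-dimethyl-1,3-thiazol-2-yl in place of 2-methoxy-5-methylphenyl on an amide-type nitrogen. For the measured compounds named here, no measured pair shows this change, so its effect is only expected, not known; a downward step beyond the scatter is anticipated, and the step from compound 3 to compound 4 is estimated as a number 0.75 log units lower from compound 3 to compound 4 (beyond the scatter) in this assay. On that basis compound 4 is expected to give 4.9 in this assay, with a range from 4.2 to 5.6.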

Compound 4, distribution coefficient: 4.24
Estimate against measurement, compound 4: 0.66 log units above; the measured number falls inside the stated range.
By their numbers in this assay, from the lowest: compound 2; then compound 4; then compound 3; then compound 1.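

In this assay, for the compounds shown here, the change to 4,5-dimethyl-1,3-thiazol-2-yl on this amide-type nitrogen reads as a number 1.41 log units lower from compound 3 to compound 4 (beyond the scatter) and is the first step that isolates one place, showing that this position alone can carry a large change in the read-out. No measurement at hand accounts for the size of this step.

As far as these compounds go, whether the fall follows the five-membered ring, its two methyl groups or the loss of the methoxy stays open. Also open, from the compounds shown here alone, is how an unsubstituted phenyl or a pyridin-2-yl would read on this nitrogen.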